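The compounds below may be only part of what the source reports. "The series", "measured", "known", "first", "only" and "open" are said of these compounds alone.

Compound 1, `Cn1c(=O)c(=O)n(C2CCCC2)c2nc(N/N=C/c3ccc(F)cc3Cl)ncc21`, gives 11000 nM in a functional assay on A549 cells (Homo sapiens) for antiproliferative activity, read by MTT assay; on this read-out higher numbers stand for weaker inhibition and lower numbers for stronger inhibition.
Compound 2, `COc1cc(/C=N/Nc2ncc3c(n2)n(C2CCCC2)c(=O)c(=O)n3C)cc(OC)c1OC`, gives 18300 nM in this assay.

Of these two numbers, compound 1 has the lower one, and compound 2 sits close to it, within the usual scatter of repeated measurements, so the two cannot be told apart. Compound 3, `Cn1c(=O)c(=O)n(C2CCCC2)c2nc(N/N=C/c3ccccc3Cl)ncc21`, has not been measured. It differs from compound 1 in one place: hydrogen in place of fluoro on an aromatic carbon. Going by the values given here, no measured pair shows the effect of this change, so there is no step to lean on. Swapping a single fluorine for a hydrogen on an aromatic ring is a small change, and with nothing measured for it the expectation is no step beyond the scatter in this assay. Compound 3 is therefore expected to give about 14000 nM, with a likely range from 6000 nM to 35000 nM. This amounts to an expected step of a 1.3-fold higher number from compound 1 to compound 3 (0.10 log units; within the scatter).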

Compound 3, half-maximal inhibitory concentration: 9860 nM
Compound 3: the middle estimate sits 1.4-fold (0.15 log units) above what was measured, within the range that was stated.
By their numbers in this assay, from the lowest: compounds 3, 1 and 2 (each within the scatter of the next).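

Hydrogen in place of fluoro on this aromatic carbon, meta to the chloro group and para to the large group, gives a 1.1-fold lower number from compound 1 to compound 3 (0.05 log units; within the scatter) in this assay as the first measured step at this position. The fluoro group of the 2-chloro-4-fluorophenyl ring is therefore not needed to keep the number at this level, since the 2-chlorophenyl compound cannot be told apart from it. No measurement at hand explains why the step is so small.

Going by these compounds, whether a group of a different kind at this position, such as an amine or a carboxylic acid, would give a step beyond the scatter remains open. Also open, on these data alone, is what the chloro group contributes, as every compound with a single step here still carries it.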